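Shifting One Phenol on Two Related Diaryl Chains

A few compounds are considered here, and "the series" means these few. Any claim that something is new, unique, unknown or untested is made for them only; others in the source may bear on it.

The study sets two pairs of compounds side by side that share one structural swap. Compound 1 `O=C(/C=C/c1cccc(O)c1)CC(=O)/C=C/c1cccc(O)c1O` and compound 2 `O=C(/C=C/c1ccc(O)cc1)CC(=O)/C=C/c1cccc(O)c1O` were both run in a functional assay, with a stated time of 30 min; on this read-out lower numbers stand for stronger inhibition and higher numbers for weaker inhibition. Compound 1 gives 29000 nM, while compound 2 gives 27000 nM. Within the data shown here, the one change between them is 4-hydroxyphenyl in place of 3-hydroxyphenyl on a double-bonded chain carbon bound to a double-bonded chain carbon, and the step of a 1.1-fold lower number from compound 1 to compound 2 (0.03 log units; within the scatter), so the two numbers cannot be told apart.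

Compound 3 `O=C(/C=C/c1cccc(O)c1)/C=C/c1ccc(O)c(O)c1` is built on a different core; how that core differs from the core of compound 1 is not broken down here. In this assay compound 3 gives 71000 nM, the highest of the three values, and its distance from both compound 1 and compound 2 lies beyond the usual scatter.

Compound 4 `O=C(/C=C/c1ccc(O)cc1)/C=C/c1ccc(O)c(O)c1` has not yet been measured. It stands to compound 3 as compound 2 stands to compound 1: the change is 4-hydroxyphenyl in place of 3-hydroxyphenyl on a double-bonded chain carbon bound to a double-bonded chain carbon, and since the place of the change is described in the same words in both pairs, it is the same change. Among the measured compounds shown here, its effect can only be judged from the one measured instance. Because the step of a 1.1-fold lower number from compound 1 to compound 2 (0.03 log units; within the scatter) stayed within the scatter, a step of similar size, a 1.1-fold lower number from compound 3 to compound 4 (0.04 log units; within the scatter), is expected here. Compound 4 is therefore estimated to give 65000 nM in this assay. The estimate for compound 4 is expected to fall between 30000 nM and 140000 nM.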

Compound 4, half-maximal inhibitory concentration: 24000 nM
Compound 4: the middle estimate sits 2.7-fold (0.43 log units) above what was measured; the whole stated range lies above it.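

Placed on the other core, the same swap of 3-hydroxyphenyl for 4-hydroxyphenyl gives a 3.0-fold lower number from compound 3 to compound 4 (0.47 log units; beyond the scatter) in this assay, a step that can be told apart from the scatter, whereas the earlier step could not. Set side by side, the two steps differ, so the size of this change does not carry over from one core to the other in this series: the same change on two cores in this assay, a 1.1-fold lower number (0.03 log units; within the scatter) from compound 1 to compound 2 and a 3.0-fold lower number (0.47 log units; beyond the scatter) from compound 3 to compound 4, 2.8-fold (0.44 log units) apart, beyond the scatter of two such steps This rests on a single pair for each core, so it shows that the effect of the swap depends on the core in these four compounds, but it does not show what in the cores produces the gap or how the change would behave on any further core.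

The compounds shown leave open whether a methoxy group or a fluorine atom in the place of the moved hydroxyl would give a similar difference between the two cores. They also leave open whether an amine on the phenyl ring, or a longer chain joining the two rings, would keep the step seen on one core, the step seen on the other, or neither.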